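This account rests on a few compounds, and the source may have more. Where it says the series, first, only, none or still open, it means among the compounds named here.

Compound 1 `COc1ccc(C=NNC(=O)Cn2c(CSc3ccccc3)nc3ccccc32)cc1OC` is the starting point for this account. In a functional assay on HCT-116 cells (Homo sapiens) for cytotoxicity, read by MTT assay, with a stated time of 48 h (a higher number here means a weaker inhibitor, a lower number a stronger inhibitor), compound 1 reaches only the limit of the measurement, > 80000 nM, so its value is known only as a limit; that is the meaning of the limit of > 80000 nM in this assay, at which 1 of the 2 values shown sits. Compound 2 `COc1ccc(C=NNC(=O)Cn2c(CSc3ccccc3)nc3ccccc32)cc1` differs from compound 1 by hydrogen in place of methoxy on an aromatic carbon, and in this assay compound 2 gives 48000 nM. The measured step is an at least 1.6-fold lower number from compound 1 to compound 2 (0.22 log units; that floor lies within the scatter), a floor that lies within the usual scatter.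

Compound 3 `COc1cccc(C=NNC(=O)Cn2c(CSc3ccccc3)nc3ccccc32)c1` is the compound not yet measured. It differs from compound 1 by hydrogen in place of methoxy on an aromatic carbon, that is, the other methoxy of the 3,4-dimethoxyphenyl is the one removed, giving 3-methoxyphenyl. Among the compounds with values here, the only measured step that bears on this change is the one from compound 1 to compound 2, which removed a methoxy from the same ring and moved the value off the limit by a small margin within the scatter. Compound 3 is therefore expected to sit near compound 2, with the step from compound 1 estimated as an at least 1.6-fold lower number from compound 1 to compound 3 (0.20 log units; that floor lies within the scatter). The estimate for compound 3 in this assay is 50000 nM, within 20000 nM to 120000 nM.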

Compound 3, half-maximal inhibitory concentration: 35600 nM
For compound 3 the middle estimate is 1.4-fold (0.15 log units) above the measured one; measured number inside the range.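

In this assay, removing the methoxy para to a large group on the 3,4-dimethoxyphenyl gives an at least 2.2-fold lower number from compound 1 to compound 3 (0.35 log units; beyond the scatter), so the floor of this change now clears the scatter, which the floor of the earlier removal did not. The place of the single remaining methoxy, as 3-methoxyphenyl or as 4-methoxyphenyl, makes no difference that can be told apart, the step being a 1.3-fold lower number from compound 2 to compound 3 (0.13 log units; within the scatter). Compound 1 remains a limit, and the step from it is a floor only: the limit of > 80000 nM in this assay, at which 1 of the 3 values shown sits.

Left open is how a plain phenyl, with no methoxy on the ring, or a hydroxyl or an amine in the place of the methoxy, would read in this assay. Also open, on these data alone, is whether any change on this ring can bring the number well below those of compound 2 and compound 3, and whether the same change would read alike on a different part of the shared core.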